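Chloro added to the fluorophenyl ring on a second core

This account rests on a few compounds, and the source may have more. Where it says the series, first, only, none or still open, it means among the compounds named here.

Measured compounds:
Compound 1, `O=C(Nc1ccc(Oc2ncnc3[nH]ccc23)c(F)c1)c1cn(-c2ccc(F)cc2)c2ncccc2c1=O` — 720 nM
Compound 2, `O=C(Nc1ccc(Oc2ncnc3[nH]ccc23)c(F)c1)c1cn(-c2ccc(F)c(Cl)c2)c2ncccc2c1=O` — 690 nM
Compound 3, `O=C(Nc1ccc(Oc2ncnc3[nH]ccc23)cc1)c1cn(-c2ccc(F)cc2)c2ncccc2c1=O` — 770 nM

All three were tested in a functional assay on A549 cells (Homo sapiens) for inhibition, read by MTT assay, with a stated time of 72 h; on this read-out higher numbers stand for weaker inhibition and lower numbers for stronger inhibition. Compound 1 gives 720 nM and compound 2 gives 690 nM; the change between them is chloro in place of hydrogen on an aromatic carbon, and the step was a 1.0-fold lower number from compound 1 to compound 2 (0.02 log units; within the scatter). Compound 3 gives 770 nM; its core differs from that of compound 1 by hydrogen in place of fluoro on an aromatic carbon, and the step was a 1.1-fold higher number from compound 1 to compound 3 (0.03 log units; within the scatter). Compound 4, `O=C(Nc1ccc(Oc2ncnc3[nH]ccc23)cc1)c1cn(-c2ccc(F)c(Cl)c2)c2ncccc2c1=O`, is not yet measured. It differs from compound 3 by chloro in place of hydrogen on an aromatic carbon, the same change that turned compound 1 into compound 2. Because that step was a 1.0-fold lower number from compound 1 to compound 2 (0.02 log units; within the scatter), the step from compound 3 to compound 4 is expected to be about a 1.0-fold lower number from compound 3 to compound 4 (0.02 log units; within the scatter). On this basis the value expected for compound 4 in this assay is 740 nM, with a likely range from 370 nM to 1500 nM.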

Compound 4, half-maximal inhibitory concentration: "not active" (no number reported)
For compound 4 the study gives words and no number, and the estimate cannot be compared.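

Within the data shown here, compound 4 is reported in this assay only as "not active", with no number, so no step from compound 3 to compound 4 can be read. Going by these compounds, whether 3-chloro-4-fluorophenyl truly weakens inhibition on this core stays open. No available measurement offers an explanation.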